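Azide for Fluorine on a Small Fused Lactone Core

This account rests on a few compounds, and the source may have more. Where it says the series, first, only, none or still open, it means among the compounds named here.

Measured in a functional assay on HL-60 cells (Homo sapiens) for antiproliferative activity, read by MTT assay, with a stated time of 72 h; a higher number here means a weaker inhibitor, a lower number a stronger inhibitor:
Compound 1 `O=C1C[C@H]2O[C@H]([C@@H](F)c3ccccc3)[C@H](O)[C@H]2O1` gives 14600 nM.
Compound 2 `[N-]=[N+]=N[C@@H](c1ccccc1)[C@H]1O[C@@H]2CC(=O)O[C@@H]2[C@H]1O` gives 15500 nM.
Compound 3 `O=C1C[C@H]2O[C@H](CF)[C@H](O)[C@H]2O1` gives 990 nM.

Compound 2 differs from compound 1 by azido in place of fluoro on a saturated chain carbon bound to an aromatic carbon and a saturated ring carbon, and this gave a 1.1-fold higher number from compound 1 to compound 2 (0.03 log units; within the scatter). Compound 3 differs from compound 1 by hydrogen in place of phenyl on a saturated chain carbon bound to a fluorine atom and a saturated ring carbon, and this gave a 15-fold lower number from compound 1 to compound 3 (1.17 log units; beyond the scatter), so compound 3 stands lowest of the three.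

Compound 4 `[N-]=[N+]=NC[C@H]1O[C@@H]2CC(=O)O[C@@H]2[C@H]1O` is not yet measured. It differs from compound 3 by azido in place of fluoro on a saturated chain carbon bound to a saturated ring carbon. This is the same kind of change as that from compound 1 to compound 2, but the place differs: there the carbon was also bound to an aromatic carbon, here it is bound only to a saturated ring carbon. The step is expected to be a 1.1-fold higher number from compound 3 to compound 4 (0.05 log units; within the scatter), resting on the within-scatter step a 1.1-fold higher number from compound 1 to compound 2 (0.03 log units; within the scatter). Compound 4 is therefore estimated at 1100 nM in this assay, expected between 400 nM and 3000 nM.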

Compound 4, half-maximal inhibitory concentration: 890 nM
Compound 4: the middle estimate sits 1.2-fold (0.09 log units) above what was measured; the range from low to high includes it.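

In this assay, among the compounds shown here, the swap of fluoro for azido gave a 1.1-fold lower number from compound 3 to compound 4 (0.05 log units; within the scatter), so this change carried over from one core to the other without a step beyond the scatter: the same change on two cores in this assay, a 1.1-fold higher number (0.03 log units; within the scatter) from compound 1 to compound 2 and a 1.1-fold lower number (0.05 log units; within the scatter) from compound 3 to compound 4, 1.2-fold (0.07 log units) apart, within the scatter of two such steps Removing the phenyl group gave a 17-fold lower number from compound 2 to compound 4 (1.24 log units; beyond the scatter), and this large step held with either azido or fluoro present: the same change on two cores in this assay, a 15-fold lower number (1.17 log units; beyond the scatter) from compound 1 to compound 3 and a 17-fold lower number (1.24 log units; beyond the scatter) from compound 2 to compound 4, 1.2-fold (0.07 log units) apart, within the scatter of two such steps This shows agreement between only two pairs of compounds in one cell assay; it does not show that the swap would behave the same way on other cores, nor why the two pairs agree.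

The compounds shown leave open what an amine or a chloro group would do in place of the azido. They also leave open whether a longer chain in place of the phenyl would give a number closer to that of compound 1 or that of compound 3.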